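The compounds below may be only part of what the source reports. "The series", "measured", "known", "first", "only" and "open" are said of these compounds alone.

Measured so far in a functional assay on PC-3 cells (Homo sapiens) for inhibition, read by MTT assay, with a stated time of 72 h, tested at 10 uM; on this read-out higher numbers stand for more inhibition of growth at the one concentration tested and lower numbers for less inhibition of growth:
compound 1, `COc1cc2ncnc(Nc3ccc([N+](=O)[O-])cc3)c2c(OC)c1OC`: 24.9%
compound 2, `COc1cc2ncnc(Nc3ccc(Br)cc3)c2c(OC)c1OC`: 22.2%

Going by the values given here, of the two numbers in this assay, compound 2 stands at one end and compound 1 at the other, and the single measured step, a number 2.7 percentage points lower from compound 1 to compound 2 (within the scatter), lies within the scatter. That step exchanges one group for another at the same place on the outer ring and moves the read-out by no more than the scatter.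

Compound 3, `COc1cc2ncnc(Nc3ccc(F)cc3)c2c(OC)c1OC`, is not yet measured. It differs from compound 2 by fluoro in place of bromo on an aromatic carbon. Among the compounds with values here, no measured step exchanges one halogen for another, so the one step seen bears on it only indirectly: a change of the group at that place once produced nothing beyond the scatter. The step expected in this assay is therefore a number 2.2 percentage points lower from compound 2 to compound 3 (within the scatter), with no clear direction. Compound 3 is estimated at 20%, with a range from 8% to 32%.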

Compound 3, percent growth inhibition at one concentration: 9.1%
Beside the measured number, compound 3's estimate is 10.9 percentage points above it; measured number inside the range.
By their numbers in this assay, from the lowest: compound 3; then compounds 2 and 1 (each within the scatter of the next).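

Going by these compounds alone, the group on this aromatic carbon can matter in this assay: fluoro in place of bromo gives a number 13.1 percentage points lower from compound 2 to compound 3 (beyond the scatter) and is the first step to pass the scatter. Fluoro in place of nitro gives a number 15.8 percentage points lower from compound 1 to compound 3 (beyond the scatter) and so sets compound 3 apart from both compound 1 and compound 2, whose own values remain within the scatter of each other. Nothing available accounts for this separation of fluoro from the other two groups.

As far as these compounds go, it remains open where chloro, methyl, methoxy or an amine on this aromatic carbon would fall relative to fluoro and bromo. Within the data shown here, with only three groups compared at this one place, the data do not establish any trend across substituents.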